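The source may report more compounds than this note shows. Statements on the series, on what has been measured and on what is new or still open speak of the compounds shown alone.

Three compounds that share one core and differ either in the chain carried on an aromatic nitrogen or in the ring attached to that core have been tested in a functional assay on cells (Homo sapiens) for antiproliferative activity, read by MTT assay, with a stated time of 48 h; on this read-out higher numbers stand for weaker inhibition and lower numbers for stronger inhibition. Compound 1 `CN(C)CCn1c(N)c(-c2nc3ccccc3[nH]2)c2nc(C#N)c(C#N)nc21` gives 43500 nM in this assay. Compound 2 `CN(C)CCCn1c(N)c(-c2nc3ccccc3[nH]2)c2nc(C#N)c(C#N)nc21` differs from compound 1 by a ((dimethylamino)methyl in place of dimethylamino on a saturated chain carbon, two bonds along the chain from an aromatic nitrogen). This change produced a 24-fold lower number from compound 1 to compound 2 (1.38 log units; beyond the scatter), and compound 2 gives 1820 nM. Compound 3 `CN(C)CCCn1c(N)c(-c2nc3ccccc3s2)c2nc(C#N)c(C#N)nc21` carries a different ring on the core than compound 2; the step of a 1.6-fold higher number from compound 2 to compound 3 (0.21 log units; within the scatter) lies within the scatter, and compound 3 gives 2930 nM in this assay. The difference between the core of compound 1 and the core of compound 3 is not broken down here.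

Compound 4 `CN(C)CCCCn1c(N)c(-c2nc3ccccc3s2)c2nc(C#N)c(C#N)nc21` has not yet been measured. It differs from compound 3 by a ((dimethylamino)methyl in place of dimethylamino on a saturated chain carbon, three bonds along the chain from an aromatic nitrogen). For the measured compounds named here, this is the same kind of change as the one from compound 1 to compound 2, but the place differs: there the change sat two bonds along the chain from an aromatic nitrogen, here it sits three bonds along the chain from an aromatic nitrogen. Because the earlier step of a 24-fold lower number from compound 1 to compound 2 (1.38 log units; beyond the scatter) was large, a further lengthening of the chain may lower the number again, but a single step of this kind gives no grounds to expect the same size a second time. For compound 4 the step is expected to be a 2.0-fold lower number from compound 3 to compound 4 (0.29 log units; within the scatter), smaller than the earlier one. The estimate for compound 4 in this assay is 1500 nM, with a likely range from 400 nM to 5000 nM.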

Compound 4, half-maximal inhibitory concentration: 2740 nM
The estimate for compound 4 lay 1.8-fold (0.26 log units) below the measured number; the measured number falls inside the stated range.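

In this assay, lengthening the chain gives a 1.1-fold lower number from compound 3 to compound 4 (0.03 log units; within the scatter), so the 3-(dimethylamino)propyl chain of compound 3 and the 4-(dimethylamino)butyl chain of compound 4 cannot be told apart on this read-out. Set beside the earlier step, the same kind of change did not carry its size over from one compound pair to the other: the same change on two cores in this assay, a 24-fold lower number (1.38 log units; beyond the scatter) from compound 1 to compound 2 and a 1.1-fold lower number (0.03 log units; within the scatter) from compound 3 to compound 4, 22-fold (1.35 log units) apart, beyond the scatter of two such steps This does not show that the ring on the core sets the size of the step, as the two steps differ in two things at once: the first goes from 2-(dimethylamino)ethyl to 3-(dimethylamino)propyl on a 1H-benzimidazol-2-yl core, and the second goes from 3-(dimethylamino)propyl to 4-(dimethylamino)butyl on a 1,3-benzothiazol-2-yl core.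

The compounds shown leave open how the 2-(dimethylamino)ethyl chain behaves with the 1,3-benzothiazol-2-yl ring and how the 4-(dimethylamino)butyl chain behaves with the 1H-benzimidazol-2-yl ring, the two pairings that could separate the effect of the ring from that of the chain length. Also open, from the compounds shown here alone, is whether a still longer chain, or a different amine at its end such as a piperidine or a morpholine, would shift the number.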